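A Phenyl in Place of the Chlorinated Hydroxyphenyl

This account rests on a few compounds, and the source may have more. Where it says the series, first, only, none or still open, it means among the compounds named here.

Compound 1 `COc1cc(OC)c(OC)cc1/C=C/C(=O)c1cc(Cl)ccc1O`: > 150000 nM
Compound 2 `COc1cc(OC)c(-c2cc(=O)c3ccc(O)cc3o2)cc1OC`: > 150000 nM
Compound 3 `COc1cc(OC)c(C(=O)/C=C/c2cc(OC)c(OC)cc2OC)c(OC)c1`: 96500 nM

All three were tested in a functional assay on SW982 cells (Homo sapiens) for inhibition, read by MTT assay, with a stated time of 72 h; on this read-out higher numbers stand for weaker inhibition and lower numbers for stronger inhibition. For compound 1 the result is a limit of the assay rather than a number, > 150000 nM. Compound 2 also stops at a limit, > 150000 nM. Compound 3 gives a measured number, 96500 nM. Compound 1 therefore stands at the limit of > 150000 nM in this assay, at which 2 of the 3 values shown sit, with no measurable inhibition seen.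

Compound 4 `COc1cc(OC)c(OC)cc1/C=C/C(=O)c1ccccc1` differs from compound 1 by phenyl in place of 5-chloro-2-hydroxyphenyl on a carbonyl carbon. For the measured compounds named here, no measured pair shows what this change does, and the starting value is itself a limit. Compound 4 is expected to come out near 150000 nM, within 50000 nM to 300000 nM. The expected step of a number no higher from compound 1 to compound 4 (the limit leaves the size open) is none beyond the scatter of this assay, and most likely another limit.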

Compound 4, half-maximal inhibitory concentration: > 150000 nM
Compound 4 gave a limit, no number; the forecaster's own chance of this, stated with the estimate: 65%; the middle value sits exactly at the limit.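

For the compounds shown here, compound 1 and compound 4 both end at a limit rather than a number, and no step between them can be read. Going by these compounds, whether phenyl in place of 5-chloro-2-hydroxyphenyl changes inhibition at all stays open.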